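Adding a Third Methyl to a Styryl Sulfone

A few compounds are considered here, and "the series" means these few. Any claim that something is new, unique, unknown or untested is made for them only; others in the source may bear on it.

The measured compounds and their values:

- compound 1, `COc1cc(OC)c(/C=C/S(=O)(=O)Cc2ccc(Cl)cc2)c(OC)c1`: in a functional assay on DLD-1 cells (Homo sapiens) for antiproliferative activity, read by trypan blue exclusion (on this read-out lower numbers stand for stronger inhibition and higher numbers for weaker inhibition), compound 1 gives 15000 nM
- compound 2, `COc1ccc(CS(=O)(=O)/C=C/c2ccc([N+](=O)[O-])cc2)cc1`: in this assay compound 2 gives 5000 nM
- compound 3, `COc1ccc(CS(=O)(=O)/C=C/c2ccc(C)cc2C)cc1`: in this assay compound 3 gives 15000 nM

Compound 3 sits level with compound 1 at the digits shown, and the two of them stand together at the highest numbers among the three. The nearest neighbour of compound 3 is therefore compound 1, with no difference beyond the usual scatter. The furthest is compound 2, whose number is lower than that of compound 3 by a margin beyond the scatter.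

The next compound, compound 4, `COc1ccc(CS(=O)(=O)/C=C/c2c(C)cc(C)cc2C)cc1`, differs from compound 3 in one place: methyl in place of hydrogen on an aromatic carbon. Within the data shown here, no pair of measured compounds differs from each other by exactly this kind of change, so there is no measured step of this sort to lean on. Among the measured compounds shown here, with the only close neighbour giving a number within the scatter, the sensible expectation is a step from compound 3 to compound 4 that is small, most likely none beyond the scatter, with a slight lean towards a higher number. The estimate for compound 4 in this assay is 18000 nM, within a range from 6000 nM to 50000 nM, which amounts to an expected step of a 1.2-fold higher number from compound 3 to compound 4 (0.08 log units; within the scatter).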

Compound 4, half-maximal inhibitory concentration: > 20000 nM
Compound 4: no number, only a limit; the forecaster's own chance of this, stated with the estimate: 20%; at least 1.1-fold (0.04 log units) between middle value and limit.
By their numbers in this assay, from the lowest: compound 2; then compounds 1 and 3 (each within the scatter of the next). At a limit, above all of these: compound 4.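

In this assay compound 4 gives > 20000 nM, which is a limit of the assay and not a number. Methyl in place of hydrogen on this aromatic carbon, ortho to a large group and meta to two methyl groups, gives an at least 1.3-fold higher number from compound 3 to compound 4 (0.12 log units; that floor lies within the scatter), so this first reading of the change at this position shows no gain in inhibition, though the floor of the step does not by itself clear the usual scatter. What can be said about compound 4 rests on one reading at the edge of what the assay reports, so only a floor can be stated and not the true size of the step: the limit of > 20000 nM in this assay, at which 1 of the 4 values shown sits.

The compounds shown leave open how far the true value of compound 4 lies from that of compound 3, and so whether adding this methyl truly weakens inhibition or leaves it unchanged. They also leave open whether an amine or a carboxylic acid on this same aromatic carbon, in place of the hydrogen of compound 3, would give a lower number in this assay rather than a higher one.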